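This account rests on a few compounds, and the source may have more. Where it says the series, first, only, none or still open, it means among the compounds named here.

Values in an ADME assay on the whole organism (Mus musculus, strain BALB/c), read by LC-MS, with a stated time of 24 h, at a dose of 10 mg/kg by the oral route (a higher number here means more compound in the circulation at the dose given, a lower number less compound in the circulation), for the three measured compounds:

Compound 1 `Cn1nccc1-c1cc(C(F)(F)F)ccc1[C@H]1CCOc2cc(S(=O)(=O)Nc3nccs3)ccc21` gives 7810 ng.h/mL
Compound 2 `Cn1nccc1-c1cc(C(F)(F)F)ccc1[C@H]1CCOc2cc(S(=O)(=O)Nc3ncccn3)ccc21` gives 55200 ng.h/mL
Compound 3 `Cn1nccc1-c1cc(C(F)(F)F)ccc1[C@H]1CCc2cc(S(=O)(=O)Nc3ncccn3)ccc21` gives 42000 ng.h/mL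

Compound 1 stands lowest of the three. Compound 4 `O=S(=O)(Nc1nccs1)c1ccc2c(c1)OCC[C@@H]2c1ccc(C(F)(F)F)cc1-n1ccnn1` has not been measured and differs from compound 1 in one place, with 1H-1,2,3-triazol-1-yl in place of 1-methyl-1H-pyrazol-5-yl on an aromatic carbon. Within the data shown here, the only measured single change (a 7.1-fold higher number from compound 1 to compound 2 (0.85 log units; beyond the scatter)) lies elsewhere, on a sulfonamide nitrogen, so it offers neither a size nor a direction for this swap. Compound 2 and compound 3 both keep the 1-methyl-1H-pyrazol-5-yl. No step beyond the scatter is therefore expected in this assay (a 1.2-fold lower number from compound 1 to compound 4 (0.08 log units; within the scatter)), although the range stays wide. For compound 4 the estimated value is 6500 ng.h/mL (expected range 1800 ng.h/mL to 24000 ng.h/mL).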

Compound 4, area under the concentration-time curve: 3600 ng.h/mL
For compound 4 the middle estimate is 1.8-fold (0.26 log units) above the measured one; the measured number falls inside the stated range.
By their numbers in this assay, from the lowest: compound 4; then compound 1; then compounds 3 and 2 (each within the scatter of the next).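

Compound 4 shows that the ring on this aromatic carbon, ortho to a large group, also matters in this assay, and not only the group on the sulfonamide nitrogen. Placing 1H-1,2,3-triazol-1-yl there instead of 1-methyl-1H-pyrazol-5-yl gives a 2.2-fold lower number from compound 1 to compound 4 (0.34 log units; beyond the scatter), a modest step beyond the scatter. No available evidence accounts for this step.

Going by these compounds, whether the same swap would give a similar step alongside a pyrimidin-2-yl on the sulfonamide nitrogen remains open. So does the effect of an amine or a carboxylic acid on this aromatic carbon.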